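One Substituent Swap, Tried on Two Related Cores

The compounds below may be only part of what the source reports. "The series", "measured", "known", "first", "only" and "open" are said of these compounds alone.

Of the compounds shown here, three have been measured in a functional assay on DU-145 cells (Homo sapiens) for inhibition, read by MTT assay, with a stated time of 72 h; on this read-out lower numbers stand for stronger inhibition of growth and higher numbers for weaker inhibition of growth. Compound 1 `COc1ccc(CNC(=O)/C(C#N)=C/c2ccc3ccccc3c2)cc1` gives 80000 nM. Compound 3 `N#C/C(=C\c1ccc2ccccc2c1)C(=O)NCc1ccc(Cl)c(Cl)c1` differs from compound 1 by 3,4-dichlorophenyl in place of 4-methoxyphenyl on a saturated chain carbon bound to an amide-type nitrogen, and in this assay compound 3 gives 77000 nM. That exchange made a 1.0-fold lower number from compound 1 to compound 3 (0.02 log units; within the scatter), so the two compounds cannot be told apart on this read-out.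

Compound 2 `COc1ccc(CNC(=O)/C(C#N)=C/c2cccc3ccccc23)cc1` is built from the same atoms as compound 1, joined differently; the difference between the two cores is not broken down here. In this assay compound 2 gives 16000 nM, the lowest of the three numbers, and its distance to both compound 1 and compound 3 lies beyond the usual scatter.

Compound 4 `N#C/C(=C\c1cccc2ccccc12)C(=O)NCc1ccc(Cl)c(Cl)c1` has not yet been measured. Among the compounds with values here, it differs from compound 2 by 3,4-dichlorophenyl in place of 4-methoxyphenyl on a saturated chain carbon bound to an amide-type nitrogen, which is the same change as the one that turns compound 1 into compound 3.

Because the same exchange on the other core gave a 1.0-fold lower number from compound 1 to compound 3 (0.02 log units; within the scatter), the step from compound 2 to compound 4 is expected to be no change at the digits printed from compound 2 to compound 4 (within the scatter). On that basis compound 4 is expected to give about 16000 nM in this assay. A single prior instance on a different core is a thin footing, so the estimate for compound 4 is given a range from 6000 nM to 45000 nM.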

Compound 4, concentration for 50% growth inhibition: 12000 nM
Compound 4: the middle estimate sits 1.3-fold (0.12 log units) above what was measured, within the range that was stated.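

In this assay, putting 3,4-dichlorophenyl in place of 4-methoxyphenyl on the second core gave a 1.3-fold lower number from compound 2 to compound 4 (0.12 log units; within the scatter), so this pair, like the first, cannot be told apart on this read-out. Set side by side, the two cores respond to the exchange in the same way: the same change on two cores in this assay, a 1.0-fold lower number (0.02 log units; within the scatter) from compound 1 to compound 3 and a 1.3-fold lower number (0.12 log units; within the scatter) from compound 2 to compound 4, 1.3-fold (0.11 log units) apart, within the scatter of two such steps. Within this small series, then, the swap carries from one core to the other without a shift that can be distinguished from ordinary assay noise, but this rests on only two matched pairs in a single cell assay; it does not show that a third core would respond alike, or that the two groups would remain interchangeable in any other test.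

The compounds shown leave open whether a group of a different kind on a saturated chain carbon bound to an amide-type nitrogen, such as an amine or a carboxylic acid in place of the substituted phenyl ring, would move the number beyond the scatter. They also leave open what a longer chain between the amide nitrogen and the ring would do, and whether the nitrile could be replaced by another group such as a carboxylic acid.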